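Cytotoxicity after Replacing Cyclohexyl with a Methoxyethoxy Chain

A few compounds are considered here, and "the series" means these few. Any claim that something is new, unique, unknown or untested is made for them only; others in the source may bear on it.

For the measured compounds named here, compound 3 `CN1Cc2ccc(OCC3CCCCC3)cc2[C@@H](O)C1` is the only member of this small set that returns a number in an ADME assay on Vero cells (Chlorocebus sabaeus) for cytotoxicity, read by sulforhodamine B assay, with a stated time of 72 h; on this read-out higher numbers stand for weaker inhibition and lower numbers for stronger inhibition: compound 3 gives 65600 nM. For compound 1 `Cc1ccccc1COc1ccc2c(c1)[C@@H](O)CN(C)C2` the result is a limit of the assay, > 100000 nM. For compound 2 `CN1Cc2ccc(OCCc3ccccc3)cc2[C@@H](O)C1` the result is also a limit of the assay, > 50000 nM. Compound 4 `COCCOCOc1ccc2c(c1)[C@@H](O)CN(C)C2` differs from compound 3 by 2-methoxyethoxy in place of cyclohexyl on a saturated chain carbon bound to an oxygen on an aromatic ring. The measured steps at that position are an at least 1.5-fold lower number from compound 1 to compound 3 (0.18 log units; that floor lies within the scatter) and a step that the limit leaves unreadable from compound 2 to compound 3, while a step that the two limits leave unreadable from compound 1 to compound 2. None of these shows a change readable beyond the scatter, so no step beyond the scatter is expected for compound 4 in this assay. The expected step is a 1.2-fold higher number from compound 3 to compound 4 (0.09 log units; within the scatter). Compound 4 is therefore estimated at 80000 nM, between 40000 nM and 200000 nM.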

Compound 4, half-maximal inhibitory concentration: > 50000 nM
Compound 4: no number, only a limit; the forecaster's own chance of this, stated with the estimate: 45%; the middle value does not contradict the limit.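

In this assay compound 4 gives > 50000 nM, which is a limit of the assay and not a number. Its steps from compound 1, compound 2 and compound 3 cannot be read. The compounds shown leave open how far 2-methoxyethoxy in place of cyclohexyl moves the value.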